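Replacing the aryl group on the sulfonamide nitrogen of compound 1

This account rests on a few compounds, and the source may have more. Where it says the series, first, only, none or still open, it means among the compounds named here.

Going by the values given here, compound 1 `CCc1ccc(N(CC(C)C)S(=O)(=O)c2ccc3c(c2)C(O)CC(C2CCOCC2)O3)cc1` holds the higher of the two numbers so far in a physicochemical assay for lipophilicity, at pH 7.4 (on this read-out higher numbers stand for higher lipophilicity and lower numbers for lower lipophilicity), at 4.12 against compound 2 `CCc1ccc(N(CC(C)C)S(=O)(=O)c2ccc3c(c2)C(O)CC(C2CCNCC2)O3)cc1` at 1.04 on the same scale. Compound 3 `CC(C)CN(c1cccc(F)c1)S(=O)(=O)c1ccc2c(c1)C(O)CC(C1CCOCC1)O2` carries 3-fluorophenyl in place of 4-ethylphenyl on a sulfonamide nitrogen. Among the compounds with values here, the only measured step (a number 3.08 log units lower from compound 1 to compound 2 (beyond the scatter)) is large but lies on a saturated ring carbon, so no measured step bears directly on this change. A smaller downward step, still beyond the scatter, is expected (a number 0.72 log units lower from compound 1 to compound 3 (beyond the scatter)). In this assay compound 3 is estimated at 3.4 (range 3 to 3.8).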

Compound 3, distribution coefficient: 3.39
For compound 3 the middle estimate is 0.01 log units above the measured one; low and high end bracket the measured number.
By their numbers in this assay, from the lowest: compound 2; then compound 3; then compound 1.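

The sulfonamide nitrogen substituent also moves the number in this assay: 3-fluorophenyl in place of 4-ethylphenyl gives a number 0.73 log units lower from compound 1 to compound 3 (beyond the scatter). This change on the aryl group is much smaller than the change on the saturated ring carbon, a number 3.08 log units lower from compound 1 to compound 2 (beyond the scatter). No measurement available here accounts for the size of the step.

Going by these compounds alone, the single swap does not separate loss of the ethyl group from gain of the fluorine. Open too, from the compounds shown here alone, is what plain phenyl, or a pyridyl ring, would give on this nitrogen, and whether the step holds alongside piperidin-4-yl.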